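Swapping fluoro for chloro on a quinoxaline sulfone

A few compounds are considered here, and "the series" means these few. Any claim that something is new, unique, unknown or untested is made for them only; others in the source may bear on it.

Of the compounds shown here, three sharing one core have been measured in a functional assay on PC-3 cells (Homo sapiens) for cytotoxicity, read by MTT assay, with a stated time of 72 h; on this read-out lower numbers stand for stronger inhibition and higher numbers for weaker inhibition. Compound 1 `Nc1ccc(Nc2nc3ccccc3nc2S(=O)(=O)c2ccccc2)cc1` gives 5830 nM; compound 2 `Nc1cccc(Nc2nc3ccccc3nc2S(=O)(=O)c2ccccc2)c1` gives 2150 nM; compound 3 `O=S(=O)(c1ccccc1)c1nc2ccccc2nc1Nc1ccc(F)cc1` gives 14200 nM. Compound 3 stands highest of the three, that is, weakest: the step of a 2.4-fold higher number from compound 1 to compound 3 (0.39 log units; beyond the scatter) and the step of a 6.6-fold higher number from compound 2 to compound 3 (0.82 log units; beyond the scatter) both lie beyond the scatter, as does the step of a 2.7-fold lower number from compound 1 to compound 2 (0.43 log units; beyond the scatter).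

Compound 4 `O=S(=O)(c1ccccc1)c1nc2ccccc2nc1Nc1ccc(Cl)cc1` differs from compound 3 by chloro in place of fluoro on an aromatic carbon, on an aromatic carbon of a six-membered aromatic ring of carbon only, para to a large group. Within the data shown here, none of the measured steps exchanges fluoro for chloro; the only step touching this position, a 2.4-fold higher number from compound 1 to compound 3 (0.39 log units; beyond the scatter), replaces amino by fluoro, and says nothing about how chloro compares with fluoro. The change is therefore expected to give a step of a 1.2-fold lower number from compound 3 to compound 4 (0.07 log units; within the scatter) in this assay, not clearly beyond the scatter in either direction, and compound 4 is estimated at 12000 nM, within a range from 4500 nM to 32000 nM.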

Compound 4, half-maximal inhibitory concentration: 15300 nM
Estimate against measurement, compound 4: 1.3-fold (0.11 log units) below; the measured number falls inside the stated range.
By their numbers in this assay, from the lowest: compound 2; then compound 1; then compounds 3 and 4 (each within the scatter of the next).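

In this assay, chloro in place of fluoro on this aromatic carbon, para to a large group, gives a 1.1-fold higher number from compound 3 to compound 4 (0.03 log units; within the scatter), so this assay does not tell these two groups apart at this position. Chloro also leaves the gap to the amino compounds in place, with a 2.6-fold higher number from compound 1 to compound 4 (0.42 log units; beyond the scatter) and a 7.1-fold higher number from compound 2 to compound 4 (0.85 log units; beyond the scatter), so compound 1 and compound 2 keep lower numbers than either compound 3 or compound 4. No measurement shown here explains why fluoro and chloro read alike.

Going by these compounds, it remains open whether other groups at this position, such as methoxy or a carboxylic acid, would stay level with fluoro and chloro or come closer to the amino compounds. On these data alone, it is also open whether fluoro and chloro would still read alike elsewhere on this ring.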